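Shifting a Methyl on the Urea Aryl Ring

A few compounds are considered here, and "the series" means these few. Any claim that something is new, unique, unknown or untested is made for them only; others in the source may bear on it.

Measured so far:
Compound 1, `Cc1cccc(NC(=O)Nc2cccc(CNc3ncnc4ccccc34)c2)c1`, gives 30200 nM.
Compound 2, `Cc1ccc(NC(=O)Nc2cccc(CNc3ncnc4ccccc34)c2)cc1`, gives 31200 nM.
Compound 3, `COc1cc2ncnc(NCc3cccc(NC(=O)Nc4cccc(C)c4)c3)c2cc1OC`, gives 44600 nM.

All three were tested in a functional assay on MGC-803 cells (Homo sapiens) for antiproliferative activity, read by MTT assay; a lower number here means a stronger inhibitor, a higher number a weaker inhibitor. Compound 1 and compound 2 share one core; compound 3 carries a different core, and the difference between the two cores is not broken down here. Compound 3 and compound 2 lie within the usual scatter of each other, as do compound 3 and compound 1, so the three values cannot be put in any order.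

Compound 4, `COc1cc2ncnc(NCc3cccc(NC(=O)Nc4ccc(C)cc4)c3)c2cc1OC`, has not yet been measured. It differs from compound 3 in one place: 4-methylphenyl in place of 3-methylphenyl on an amide-type nitrogen

The same change, on the same kind of amide-type nitrogen, has already been made once, from compound 1 to compound 2: 4-methylphenyl in place of 3-methylphenyl on an amide-type nitrogen That step gave a 1.0-fold higher number from compound 1 to compound 2 (0.01 log units; within the scatter), so moving the methyl from one position of the phenyl ring to the other left the number essentially unchanged on that core.

On the core of compound 3 the step is expected to be of similar size, a 1.0-fold higher number from compound 3 to compound 4 (0.00 log units; within the scatter), because the earlier step of a 1.0-fold higher number from compound 1 to compound 2 (0.01 log units; within the scatter) stayed within the scatter. Among the compounds with values here, with only one precedent, the range is kept wide. Compound 4 is therefore estimated at 45000 nM in this assay, with an expected spread from 22000 nM to 90000 nM.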

Compound 4, half-maximal inhibitory concentration: 34200 nM
The estimate for compound 4 lay 1.3-fold (0.12 log units) above the measured number; the measured number falls inside the stated range.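

In this assay, putting 4-methylphenyl in place of 3-methylphenyl on the amide-type nitrogen gave a 1.3-fold lower number from compound 3 to compound 4 (0.12 log units; within the scatter), so on this core the shift of the methyl cannot be told apart from no effect. The same change on the other core behaved no differently, as far as these numbers can tell: the same change on two cores in this assay, a 1.0-fold higher number (0.01 log units; within the scatter) from compound 1 to compound 2 and a 1.3-fold lower number (0.12 log units; within the scatter) from compound 3 to compound 4, 1.3-fold (0.13 log units) apart, within the scatter of two such steps. Within the data shown here, this shows that, on these two cores, the change carried over without any visible difference, but it rests on only two pairs, and neither step rises above the scatter, so it does not show that the position of the methyl is unimportant on other cores, or that a change with a larger step would carry over just as well.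

The compounds shown leave open how a plain phenyl ring without the methyl, or a ring bearing a different group such as chlorine, methoxy or trifluoromethyl, would read in this assay. They also leave open whether a group such as an amine or a carboxylic acid on this ring would give a step large enough to compare across the two cores.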